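This account rests on a few compounds, and the source may have more. Where it says the series, first, only, none or still open, it means among the compounds named here.

Compound 1, `CCOC(=O)/C(=N\O)c1ccc(Sc2cc(F)cc(C3CCOCC3)c2)cc1`: 170 nM
Compound 2, `CO[C@]1(c2cnc(S(=O)(=O)c3ccc(/C(C)=N/OCC#N)cc3)s2)CCO[C@@H](C)C1`: 140 nM

Both compounds were tested in a functional assay (blood) for inhibition, with Homo sapiens as the target; a higher number here means a weaker inhibitor, a lower number a stronger inhibitor. In this assay compound 1 gives 170 nM, the higher of the two numbers available, while compound 2 gives 140 nM; the gap between them lies within the usual scatter, so the two cannot be ranked against each other. For the measured compounds named here, no pair of measured compounds differs in a single place, so no measured step is available to guide the next change.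

Compound 3, `C/C(=N\OCC#N)c1ccc(Sc2cc(F)cc(C3CCOCC3)c2)cc1`, is derived from compound 1 by a group of 7 heavy atoms (4 carbon, 2 nitrogen, 1 oxygen; no ring) in place of a group of 8 heavy atoms (4 carbon, 1 nitrogen, 3 oxygen; no ring), on an aromatic carbon. Going by the values given here, with no measured step to lean on, the account can only draw on the two values at hand. The step of a 1.3-fold lower number from compound 1 to compound 3 (0.12 log units; within the scatter) is expected to stay within the scatter, with no clear direction. Compound 3 is therefore estimated at 130 nM in this assay, within a range from 40 nM to 400 nM.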

Compound 3, half-maximal inhibitory concentration: 20 nM
Compound 3: the middle estimate sits 6.5-fold (0.81 log units) above what was measured; the whole stated range lies above it.
By their numbers in this assay, from the lowest: compound 3; then compounds 2 and 1 (each within the scatter of the next).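

In this assay, the exchange on this aromatic carbon, para to a large group, gives an 8.5-fold lower number from compound 1 to compound 3 (0.93 log units; beyond the scatter) and so lies beyond the scatter, showing that the value responds to the group held at this position. The entering group of 7 heavy atoms has 1 triple bond and 0 hydrogen-bond donors, while the leaving group of 8 heavy atoms has 2 double bonds outside aromatic rings and 1 hydrogen-bond donor, so this single step changes several features together and cannot separate them. No measurement of any property bears on this result, so the step stands without an explanation.

The compounds shown leave open how a carboxylic acid, a primary amide or a longer chain on the same carbon would read in this assay. They also leave open whether this exchange would give a step of similar size on a different core.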